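A few compounds are considered here, and "the series" means these few. Any claim that something is new, unique, unknown or untested is made for them only; others in the source may bear on it.

Working notes on the series. Compound 1 `C[C@H](Nc1nc(N)nc(N)c1C#N)c1cc(=O)n2cc(F)ccc2c1-c1ccc(F)cc1` in an ADME assay on microsomes from liver (Rattus norvegicus), read by LC-MS, using NADPH, with a stated time of 30 min, tested at 1 uM (a higher number here means that more of the compound is left, a lower number that less of the compound is left), gives "not determined" (no result reported); for compound 1 the assay reports nothing, so no single number places it. Going by the values given here, the nearest measured neighbour is compound 2 `C[C@H](Nc1nc(N)nc(N)c1C#N)c1cc(=O)n2cc(F)ccc2c1-c1cc(F)cc(F)c1`, which in this assay gives 87%; compound 2 differs from compound 1 only in its pendant aryl ring, and no step between the two is recorded, so its value serves only as a rough reference for the series. Compound 3 `C[C@H](Nc1nc(N)nc(N)c1C#N)c1c(C2CC2)c(=O)n2cc(F)ccc2c1-c1ccc(F)cc1` is the next compound to be measured in this assay. It differs from compound 1 as follows: cyclopropyl in place of hydrogen on an aromatic carbon of the shared core. Among the compounds with values here, no step between measured compounds covers this change, so the direction is open; a modest shift in this assay in either direction, or none beyond the scatter, is expected. Compound 3 is estimated at 75% in this assay, with a range from 45% to 95%.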

Compound 3, percent of the compound remaining: 35%
Beside the measured number, compound 3's estimate is 40 percentage points above it, outside the stated range (below it).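

In this assay, going by these compounds alone, compound 3 gives 35% but compound 1 reports no number, so no step between compound 1 and compound 3 can be read. The compounds shown leave open whether cyclopropyl in place of hydrogen changes the percent remaining at all. No supporting evidence bears on this result.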